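Trimethoxy styryl sulfones: estimating compound 4

The source may hold more compounds than are shown below. What is called first, only, known or untested is meant among the compounds shown, and "the series" means these compounds.

In a functional assay on K562 cells (Homo sapiens) for cytotoxicity, read by trypan blue exclusion, with a stated time of 96 h (on this read-out higher numbers stand for weaker inhibition and lower numbers for stronger inhibition), the measured compounds read as follows
Compound 1 `COc1cc(OC)c(/C=C/S(=O)(=O)Cc2ccc(OC)c([N+](=O)[O-])c2)c(OC)c1` gives 2500 nM
Compound 2 `COC(=O)CNc1cc(CS(=O)(=O)/C=C/c2c(OC)cc(OC)cc2OC)ccc1OC` gives 100 nM
Compound 3 `COC(=O)C(Nc1cc(CS(=O)(=O)/C=C/c2c(OC)cc(OC)cc2OC)ccc1OC)c1ccc(F)cc1` gives 800 nM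

Compound 3 at 800 nM stands second highest of the three numbers, under compound 1 and over compound 2. Among the compounds with values here, compound 4 `COc1cc(OC)c(/C=C/S(=O)(=O)Cc2ccc(OC)c(NCCC(=O)O)c2)c(OC)c1` has 2-carboxyethyl in place of (4-fluorophenyl)(methoxycarbonyl)methyl on a nitrogen on an aromatic ring and has no measurement yet.

Within the data shown here, two measured steps bear on this change. The modest step of an 8.0-fold higher number from compound 2 to compound 3 (0.90 log units; beyond the scatter) came with 4-fluorophenyl in place of hydrogen, and compound 4 has no 4-fluorophenyl. The large step of a 25-fold lower number from compound 1 to compound 2 (1.40 log units; beyond the scatter) shows one change on that aromatic carbon moving the number far. Among the measured compounds shown here, no measured compound carries 2-carboxyethyl, so that part of the change is untested and the range stays wide.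

In this assay the expected step is a 3.2-fold lower number from compound 3 to compound 4 (0.51 log units; beyond the scatter) and it is modest, toward a lower number. Compound 4 is estimated at 250 nM with an expected range from 60 nM to 1000 nM for now.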

Compound 4, half-maximal inhibitory concentration: 5000 nM
The estimate for compound 4 lay 20-fold (1.30 log units) below the measured number; measured number above the stated range.
By their numbers in this assay, from the lowest: compound 2; then compound 3; then compounds 1 and 4 (each within the scatter of the next).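

In this assay, losing the 4-fluorophenyl did not bring the number back toward that of compound 2: 2-carboxyethyl in place of (4-fluorophenyl)(methoxycarbonyl)methyl on the nitrogen gave a 6.3-fold higher number from compound 3 to compound 4 (0.80 log units; beyond the scatter). An amino link at this aromatic carbon is therefore not enough for the low number, since the group on the nitrogen decides much of the outcome: carboxymethyl in place of methoxycarbonyl on the chain carbon gave a 50-fold higher number from compound 2 to compound 4 (1.70 log units; beyond the scatter), and (2-carboxyethyl)amino in place of nitro gave only a 2.0-fold higher number from compound 1 to compound 4 (0.30 log units; within the scatter). No measurement here bears on the cause of these steps.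

Going by these compounds, compounds 2 and 4 differ in both the ester and the chain, so the share of each stays open. A carboxylic acid on the shorter chain, or a methyl ester on the longer chain, would separate the two.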